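A few compounds are considered here, and "the series" means these few. Any claim that something is new, unique, unknown or untested is made for them only; others in the source may bear on it.

Measured so far in a functional assay on the whole organism (Hindlimb, strain albino) with Mus musculus as the target, in the maximal electroshock model, with a stated time of 0.5 h; a higher number here means that more compound is needed for the effect, a lower number that less compound is needed:
compound 1 `CC(=O)N1N=C(Nc2nc3ccc(Cl)cc3s2)CC1c1ccccc1` gives 161 umol/kg
compound 2 `CC(=O)N1N=C(Nc2nc3ccccc3s2)CC1c1ccccc1` gives 315 umol/kg
compound 3 `O=C(/C=C/OC1=CC=C1)Nc1nc2ccccc2s1` gives 781 umol/kg

Compound 1 and compound 2 share one core and differ only by chloro in place of hydrogen on an aromatic carbon; the result is a 2.0-fold lower number from compound 2 to compound 1 (0.29 log units; within the scatter). Compound 3 has another core; the difference between the core of compound 3 and the core of compound 2 is not broken down here. Compound 3 stands highest of the three numbers, beyond the scatter from compound 2 and from compound 1.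

Compound 4 `O=C(/C=C/OC1=CC=C1)Nc1nc2ccc(Cl)cc2s1` is not yet measured. It differs from compound 3 by chloro in place of hydrogen on an aromatic carbon, the same change as from compound 2 to compound 1, at a place described in the same words. Compound 4 is expected in this assay at 420 umol/kg, with a range of 200 umol/kg to 900 umol/kg. Among the measured compounds shown here, the expected step of a 1.9-fold lower number from compound 3 to compound 4 (0.27 log units; within the scatter) rests on the single earlier step, because a 2.0-fold lower number from compound 2 to compound 1 (0.29 log units; within the scatter) was small and a second occurrence on another core is uncertain.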

Compound 4, dose for half-maximal effect: 544 umol/kg
Estimate against measurement, compound 4: 1.3-fold (0.11 log units) below; measured number inside the range.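

In this assay, chloro in place of hydrogen on an aromatic carbon gives a 1.4-fold lower number from compound 3 to compound 4 (0.16 log units; within the scatter). Set beside the earlier step, the change reads alike on the two cores: the same change on two cores in this assay, a 2.0-fold lower number (0.29 log units; within the scatter) from compound 2 to compound 1 and a 1.4-fold lower number (0.16 log units; within the scatter) from compound 3 to compound 4, 1.4-fold (0.13 log units) apart, within the scatter of two such steps. Among the compounds shown here, since neither step lies beyond the scatter, the two pairs show only that the change carries from one core to the other without a visible difference, not that chloro itself lowers the number on either core.

The compounds shown hold only hydrogen or chloro at this place, so the outcome with fluoro, methoxy or an amine there remains open. Also open, going by these compounds, is whether the same agreement between cores would hold for a group that gives a larger step.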